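Swapping the ring amine on a quinoline-like growth inhibitor

This account rests on a few compounds, and the source may have more. Where it says the series, first, only, none or still open, it means among the compounds named here.

Of the compounds shown here, two have been measured so far in a functional assay on PC-3 cells (Homo sapiens) for inhibition, read by sulforhodamine B assay, with a stated time of 48 h; on this read-out lower numbers stand for stronger inhibition of growth and higher numbers for weaker inhibition of growth. Compound 1 `COc1cc2nc(-c3ccc(C(F)(F)F)cc3)cc(OCCCN3CCCC3)c2cc1OC` gives 1070 nM. Compound 2 `COc1cc2nc(-c3ccc(Cl)cc3)cc(OCCCN3CCC(O)CC3)c2cc1OC` gives 2020 nM, the higher of the two numbers, though its gap to compound 1 lies within the ordinary scatter of this assay, so the two cannot be ranked.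

Compound 3 `COc1cc2nc(-c3ccc(Cl)cc3)cc(OCCCN3CCCC3)c2cc1OC` has not yet been measured. It is built from compound 2 by one change: pyrrolidin-1-yl in place of 4-hydroxypiperidin-1-yl on a saturated chain carbon, three bonds along the chain from an oxygen on an aromatic ring. The rest of the shared core, including the chloro-substituted aryl group, stays as it is.

Among the measured compounds shown here, no measured pair isolates this change, so the expectation rests on the two values alone. Since compound 1, which already carries the pyrrolidin-1-yl group, sits close to compound 2, the step from compound 2 to compound 3 is expected to be small, a 1.6-fold lower number from compound 2 to compound 3 (0.19 log units; within the scatter), at most a modest move toward stronger inhibition. Compound 3 is therefore expected to give about 1300 nM, with a plausible range from 500 nM to 3500 nM.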

Compound 3, concentration for 50% growth inhibition: 1760 nM
For compound 3 the middle estimate is 1.4-fold (0.13 log units) below the measured one, within the range that was stated.
By their numbers in this assay, from the lowest: compounds 1, 3 and 2 (each within the scatter of the next).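

In this assay, pyrrolidin-1-yl in place of 4-hydroxypiperidin-1-yl gives a 1.1-fold lower number from compound 2 to compound 3 (0.06 log units; within the scatter), so at this chain end, a five-membered ring without a hydrogen-bond donor and a six-membered ring with one cannot be told apart. Compound 3 also allows a second direct comparison: chloro in place of trifluoromethyl on an aromatic carbon gives a 1.6-fold higher number from compound 1 to compound 3 (0.22 log units; within the scatter), so neither single change separates its pair in this assay. Nothing measured here offers an explanation for these results.

On these data alone, whether any group at the end of the chain matters in this assay remains open, as the two rings tested so far may simply be too alike to show it. A morpholin-4-yl group, a dimethylamino group or a longer chain could show whether this position responds to a larger change.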